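The source may hold more compounds than are shown below. What is called first, only, known or untested is meant among the compounds shown, and "the series" means these compounds.

Measured compounds:
compound 1 `CCOC(=O)C1=C(C)N(C)C(=O)NC1c1ccco1`: 17%
compound 2 `CC1=C(C(=O)OC(C)C)C(c2ccco2)NC(=O)N1C`: 28%

In an assay on CHO cells for displacement of a labelled ligand from adenosine receptor A1 (Homo sapiens), with a stated time of 60 min, tested at 10 uM (on this read-out higher numbers stand for more inhibition at the one concentration tested (going by the name of the read-out) and lower numbers for less inhibition), compound 1 gives 17%, and compound 2 gives 28%. Compound 1 thus stands lowest of the two numbers, with compound 2 its nearest neighbour. Within the data shown here, the single measured step, a number 11 percentage points higher from compound 1 to compound 2 (beyond the scatter), arises from methyl in place of hydrogen on a saturated chain carbon bound to an oxygen next to a carbonyl group and a saturated chain carbon; it alters the ester and leaves the aromatic ring untouched.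

Compound 3 `CCOC(=O)C1=C(C)N(C)C(=O)NC1c1cccs1` differs from compound 1 by thiophen-2-yl in place of furan-2-yl on a saturated ring carbon. Among the measured compounds shown here, no measured step bears on that change: the one step available concerns the ester, is modest in size, and says nothing about replacing furan-2-yl with thiophen-2-yl. The two groups leaving and entering match in heavy-atom count, ring size and acceptor count, so the working expectation is a step from compound 1 to compound 3 that stays within the scatter, a number 3 percentage points higher from compound 1 to compound 3 (within the scatter), in no firm direction. Compound 3 is therefore estimated at 20%, with a range from 5% to 40%.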

Compound 3, a percentage reported as inhibition, at one concentration (the size of the read-out at that concentration, not a potency): 2%
For compound 3 the middle estimate is 18 percentage points above the measured one; the measured number lies below the stated range.
By their numbers in this assay, from the lowest: compound 3; then compound 1; then compound 2.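

In this assay, the group on the saturated ring carbon proves able to move the read-out: thiophen-2-yl in place of furan-2-yl gives a number 15 percentage points lower from compound 1 to compound 3 (beyond the scatter) even though the two groups match in heavy atoms, ring size and hydrogen-bond acceptors. Among these compounds, this is the first reading at this position, and its direction runs opposite to the ester change, which gave a number 11 percentage points higher from compound 1 to compound 2 (beyond the scatter); both steps lie beyond the scatter, so the number in compound 1 responds to a change at either place. Nothing measured here accounts for the loss on going from the oxygen ring to the sulfur ring.

Still open, going by these compounds, is whether the number with furan-2-yl is higher than with other groups on this carbon, such as phenyl or pyridin-2-yl, or whether the difference is specific to the pair compared here. Also open, on these data alone, is whether the same replacement lowers the number when the ester of compound 2 is present, and, as these are readings at one concentration, how the compounds would compare in potency.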